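Hydrazone aryl variation on the shared core

A few compounds are considered here, and "the series" means these few. Any claim that something is new, unique, unknown or untested is made for them only; others in the source may bear on it.

Measured so far:
- compound 1, `Cc1ccc(O)c(/C=N\NC(=O)c2oc3cccc(O)c3c2C)c1`: 7350 nM
- compound 2, `Cc1c(C(=O)N/N=C\c2c(O)cccc2Cl)oc2cccc(O)c12`: 18700 nM
- compound 3, `Cc1c(C(=O)N/N=C\c2cccc(O)c2O)oc2cccc(O)c12`: 12200 nM

In a functional assay on PC-3 cells (Homo sapiens) for inhibition (a higher number here means a weaker inhibitor, a lower number a stronger inhibitor), compound 3 gives 12200 nM, the second highest of the three numbers; its nearest neighbour is compound 2 and its furthest is compound 1, and both gaps lie within the scatter. Compound 4, `Cc1c(C(=O)N/N=C\c2ccccc2)oc2cccc(O)c12`, has not been measured. It differs from compound 3 by phenyl in place of 2,3-dihydroxyphenyl on a carbon with a double bond to nitrogen.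

Two measured steps change the same aryl group on the carbon with a double bond to nitrogen: a 1.7-fold higher number from compound 1 to compound 3 (0.22 log units; within the scatter) and a 1.5-fold lower number from compound 2 to compound 3 (0.19 log units; within the scatter), both within the scatter, while a 2.5-fold higher number from compound 1 to compound 2 (0.41 log units; beyond the scatter). None of the three measured compounds bears a phenyl with no substituent there, so the effect of removing both hydroxyls is not covered directly. Given that the aryl changes measured so far moved this assay only modestly or not at all, a step of at most modest size is expected for compound 4, with a slightly higher number held somewhat more likely than a lower one: a 1.3-fold higher number from compound 3 to compound 4 (0.12 log units; within the scatter). Compound 4 is therefore estimated at 16000 nM, with a range from 6000 nM to 45000 nM.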

Compound 4, half-maximal inhibitory concentration: 29200 nM
Compound 4: middle estimate off by 1.8-fold (0.26 log units), on the low side; the range from low to high includes it.
By their numbers in this assay, from the lowest: compounds 1, 3, 2 and 4 (each within the scatter of the next, the first and the last beyond it).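

In this assay, phenyl on the carbon with a double bond to nitrogen gives the first step from compound 3 that lies beyond the scatter (a 2.4-fold higher number from compound 3 to compound 4 (0.38 log units; beyond the scatter)), and the widest gap in the set appears against the 2-hydroxy-5-methylphenyl group (a 4.0-fold higher number from compound 1 to compound 4 (0.60 log units; beyond the scatter)). Against the 2-chloro-6-hydroxyphenyl group, the step stays within the scatter (a 1.6-fold higher number from compound 2 to compound 4 (0.19 log units; within the scatter)), so the presence of a hydroxyl on this aryl group does not by itself separate compound 2 from compound 4. No supporting evidence accounts for these steps.

On these data alone, it remains open whether a phenyl bearing one hydroxyl and no other substituent would read closer to compound 3 or to compound 4. As far as these compounds go, the effect of an amine or a carboxylic acid on this aryl group is also open.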